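The source may hold more compounds than are shown below. What is called first, only, known or untested is meant among the compounds shown, and "the series" means these compounds.

Measured so far:
compound 1, `Cc1ccc(NC(=O)Nn2c(-c3ccccc3)nc3ccccc3c2=O)cc1`, 54%
compound 2, `CCc1ccc(NC(=O)Nn2c(-c3ccccc3)nc3ccccc3c2=O)cc1`, 61%
compound 3, `CCc1ccc(NC(=O)Nn2c(CC)nc3ccccc3c2=O)cc1`, 58%

All three numbers come from a functional assay on the whole organism (strain albino) with Mus musculus as the target, at a dose of 100 mg/kg by the intraperitoneal route; on this read-out lower numbers stand for less inhibition and higher numbers for more inhibition at the one dose given (going by the name of the read-out). Compound 3 stands second highest of the three; its nearest neighbour is compound 2, the step being a number 3 percentage points lower from compound 2 to compound 3 (within the scatter), and the furthest is compound 1, whose value lies within the scatter of that of compound 3. Among the compounds with values here, the series so far therefore shows no separation beyond the scatter at all.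

Compound 4, `CCc1nc2ccccc2c(=O)n1NC(=O)Nc1ccc(I)cc1`, has not been measured. Against compound 3 the change is iodo in place of ethyl on an aromatic carbon. Within the data shown here, two measured steps touch the matter. The step of a number 7 percentage points higher from compound 1 to compound 2 (within the scatter) alters the group on the same six-membered aromatic ring of carbon only, at the position para to a large group, and stays within the scatter. The step of a number 3 percentage points lower from compound 2 to compound 3 (within the scatter) alters a different part of the shared core and also stays within the scatter. Neither step brings in iodo, so nothing measured speaks directly to a halogen at this place; what is known is that changes on this ring have so far moved nothing beyond the scatter. The expectation is accordingly a step of no change at the digits printed from compound 3 to compound 4 (within the scatter), none beyond the scatter. Compound 4 is estimated at 58%, with a range from 44% to 72%.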

Compound 4, a percentage reported as inhibition, in the whole organism at one dose (the size of the read-out at that dose, not a potency): 55%
Beside the measured number, compound 4's estimate is 3 percentage points above it; the range from low to high includes it.
By their numbers in this assay, from the lowest: compounds 1, 4, 3 and 2 (each within the scatter of the next).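

In this assay the change from 4-ethylphenyl to 4-iodophenyl gives a number 3 percentage points lower from compound 3 to compound 4 (within the scatter), so the first halogen at this place, on an aromatic carbon of a six-membered aromatic ring of carbon only, does not separate from the ethyl compound. The earlier change on this ring, a number 7 percentage points higher from compound 1 to compound 2 (within the scatter), was made with phenyl on the shared core, whereas the present one has ethyl there, so a step at this place now stays within the scatter with either group on the core, and for a change of group type as well as a change of chain length. Nothing available bears on why the read-out stays put when iodo enters for ethyl.

The compounds shown leave open whether an amine, a carboxylic acid or a longer chain such as hexyl at this place would give a step beyond the scatter, or whether every group here would stay within it. Also open, going by these compounds, is whether iodo with phenyl on the shared core would match compound 2, and whether compound 3 and compound 4 would stay together at doses other than the single one given.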